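The source may report more compounds than this note shows. Statements on the series, on what has been measured and on what is new or still open speak of the compounds shown alone.

Of the compounds shown here, three from this study have been tested in a toxicity assay on PANC-1 cells (Homo sapiens) for cytotoxicity, read by MTT assay, with a stated time of 48 h; a higher number here means a weaker inhibitor of growth, a lower number a stronger inhibitor of growth. Compound 1 `Cc1cccc2cc(/C=C3\SC(=S)NC3=O)c(Cl)nc12` reaches only the limit of this assay, reported as > 100 ug/mL. Compound 2 `O=C1NC(=S)S/C1=C\c1cc2cc(F)ccc2nc1Cl` likewise gives only a limit in this assay, > 100 ug/mL. Compound 3 `Cc1cccc2cc(/C=C3\SC(=S)N(CC(=O)O)C3=O)c(Cl)nc12` also stops at the limit, with > 100 ug/mL. Compound 3 differs from compound 1 by carboxymethyl in place of hydrogen on an amide-type nitrogen in a ring, and the step that the two limits leave unreadable from compound 1 to compound 3 cannot be read because of the limit of > 100 ug/mL in this assay, at which 3 of the 3 values shown sit. The difference between the cores of compound 1 and compound 2 is not broken down here. Compound 4 `O=C(O)CN1C(=O)/C(=C/c2cc3cc(F)ccc3nc2Cl)SC1=S` has not yet been measured; it differs from compound 2 by carboxymethyl in place of hydrogen on an amide-type nitrogen in a ring, the same change as that made from compound 1 to compound 3. The step that the limit leaves unreadable from compound 2 to compound 4 is expected to be small, since the same change left both compound 1 and compound 3 at the limit, as the line the limit of > 100 ug/mL in this assay, at which 3 of the 3 values shown sit, shows. Compound 4 is therefore estimated at 150 ug/mL in this assay, within a range from 60 ug/mL to 400 ug/mL, and most probably it will again be reported only as a limit.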

Compound 4, concentration for 50% growth inhibition: > 100 ug/mL
Compound 4: only a limit was reported; the forecaster's own chance of this, stated with the estimate: 85%; the middle value lies beyond the limit too.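

No new step can be read between compound 2 and compound 4, since both stop at a limit in this assay: the limit of > 100 ug/mL in this assay, at which 4 of the 4 values shown sit.

The compounds shown leave open how strongly any of the four inhibits growth, and whether carboxymethyl in place of hydrogen on the amide-type nitrogen changes that on either core.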